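The source may report more compounds than this note shows. Statements on the series, on what has been measured and on what is new or still open speak of the compounds shown alone.

Measured in an ADME assay on CCRF-CEM cells (Homo sapiens) for cytotoxicity, with a stated time of 5 days; on this read-out higher numbers stand for weaker inhibition and lower numbers for stronger inhibition:
- compound 1 `CC(C)(CO)Nc1nc(N)nc2c1ncn2[C@H]1C[C@H](N=[N+]=[N-])[C@@H](CO)O1`: > 100000 nM, a limit
- compound 2 `C=CCNc1nc(N)nc2c1ncn2[C@H]1C[C@H](N=[N+]=[N-])[C@@H](CO)O1`: > 100000 nM, a limit
- compound 3 `[N-]=[N+]=N[C@H]1C[C@H](n2cnc3c(NC4CC4)nc(Cl)nc32)O[C@@H]1CO`: > 100000 nM, a limit

Compound 3 stands at > 100000 nM, a limit of the assay and not a number. It cannot be ranked against the other two compounds, since (the limit of > 100000 nM in this assay, at which 3 of the 3 values shown sit).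

The next compound, compound 4 `[N-]=[N+]=N[C@H]1C[C@H](n2cnc3c(NC4CC4)nc(N)nc32)O[C@@H]1CO`, replaces one group of compound 3: amino in place of chloro on an aromatic carbon, (amino in place of chloro on an aromatic carbon). That carbon lies between two ring nitrogen atoms, meta to a cyclopropylamino group.

Within the data shown here, only one measured step exists, and it lies elsewhere on the molecule: a step that the two limits leave unreadable from compound 1 to compound 2. It therefore gives no size to carry over. More useful is that compound 1 and compound 2 already bear amino on that carbon. Compound 2 reads > 100000 nM, which is again a limit. The entering amino group thus appears here only in compounds that remain at the limit, so no step beyond the scatter is expected in this assay. If a number does appear, it can only lie on the side of stronger inhibition.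

The expected change is a number no higher from compound 3 to compound 4 (the limit leaves the size open). For compound 4 the estimated value is 100000 nM, with an expected range from 30000 nM to 200000 nM.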

Compound 4, half-maximal inhibitory concentration: > 100000 nM
Compound 4 gave a limit, no number (the forecaster's own chance of this, stated with the estimate: 75%); the middle value sits exactly at the limit.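

Compound 4 gives only a limit in this assay, as do compound 1, compound 2 and compound 3, so no step from any of them to compound 4 can be read: the limit of > 100000 nM in this assay, at which 4 of the 4 values shown sit.

The compounds shown leave open whether amino in place of chloro, or cyclopropyl in place of the other groups on the nitrogen, alters inhibition in this assay at all.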